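The compounds below may be only part of what the source reports. "The series", "measured", "known", "first", "only" and "open" are said of these compounds alone.

Compound 1 `COc1ccc(C(c2ccccc2O)c2cccc3ccccc23)c(OC)c1OC` carries a 2-hydroxyphenyl on a saturated chain carbon bound to two aromatic carbons. In a functional assay on THP-1 cells (Homo sapiens) for inhibition, read by sulforhodamine B assay, with a stated time of 48 h (on this read-out lower numbers stand for stronger inhibition and higher numbers for weaker inhibition), compound 1 gives only a limit, > 20000 nM, and no number is known for it. Among the measured companions, compound 2 `COc1ccc(C(O)(C/C=C\c2ccccc2)c2cccc3ccccc23)c(OC)c1OC` gives 19400 nM in this assay. Compound 3 `CCOC(=O)CO/N=C(/c1ccc(OC)c(OC)c1OC)c1cccc2ccccc12` likewise gives only a limit in this assay, > 20000 nM. Among the compounds with values here, two of the three measured values therefore sit at the limit of > 20000 nM in this assay, at which 2 of the 3 values shown sit, and the one numerical value stands close to it, so compound 1 belongs to a set in which nothing yet shows inhibition of any strength.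

Compound 4 `COc1ccc(C(c2ccc(O)cc2)c2cccc3ccccc23)c(OC)c1OC` differs from compound 1 by 4-hydroxyphenyl in place of 2-hydroxyphenyl on a saturated chain carbon bound to two aromatic carbons. Within the data shown here, no measured step of this kind exists here, and the single numerical value of compound 2 offers no anchor for movement in either direction. The step of an at least 1.1-fold lower number from compound 1 to compound 4 (0.04 log units; that floor lies within the scatter) is thus expected to stay within the usual scatter. Compound 4 is expected to give about 18000 nM in this assay, within a range from 6000 nM to 50000 nM, with a fair chance that only a limit is reported.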

Compound 4, half-maximal inhibitory concentration: 9450 nM
Compound 4: middle estimate off by 1.9-fold (0.28 log units), on the high side; the range from low to high includes it.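

In this assay, 4-hydroxyphenyl in place of 2-hydroxyphenyl on a saturated chain carbon bound to two aromatic carbons gives an at least 2.1-fold lower number from compound 1 to compound 4 (0.32 log units; beyond the scatter). Within the data shown here, this is the first step in the set that can be read, and it shows that the two compounds, with the same atoms joined differently, are separated by more than the usual scatter. The true size of the step stays unknown, as compound 1 gives only a limit: the limit of > 20000 nM in this assay, at which 2 of the 4 values shown sit.

The compounds shown leave open whether a methoxy group or an amine in place of the hydroxyl of the 4-hydroxyphenyl would keep, strengthen or lose this inhibition. They also do not tell whether the same change would give a similar step on any core other than that of compound 1.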